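Solubility notes: the benzylic substituent step from compound 3 to compound 4

A few compounds are considered here, and "the series" means these few. Any claim that something is new, unique, unknown or untested is made for them only; others in the source may bear on it.

The series shares one core, varied at the group on the saturated chain carbon bound to the aromatic nitrogen and at the cycloalkyl amide. In a physicochemical assay for solubility (a lower number here means a less soluble compound, a higher number a more soluble compound), compound 1 `CNC(=O)c1cc(C(=O)NC2CC2)c(C)n(Cc2ccccc2)c1=O` gives >= 126 ug/mL, which is a limit of the assay rather than a number. In this assay compound 2 `CNC(=O)c1cc(C(=O)NC2CCC2)cn(Cc2ccccc2)c1=O` gives 28 ug/mL. In this assay compound 3 `CNC(=O)c1cc(C(=O)NC2CC2)cn(CC2CCOCC2)c1=O` gives >= 165 ug/mL, again a limit and not a number, sitting at the limit of >= 165 ug/mL in this assay, at which 1 of the 3 values shown sits. For compound 3, therefore, only a limit is known, and of the three values shown one further one, that of compound 1, is also a limit; compound 2 alone carries a plain number. Among the compounds with values here, no pair among the measured compounds differs in a single place, so no measured step is available.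

Compound 4 `CNC(=O)c1cc(C(=O)NC2CC2)cn(Cc2ccc(C)cc2)c1=O` differs from compound 3 by 4-methylphenyl in place of oxan-4-yl on a saturated chain carbon bound to an aromatic nitrogen. Within the data shown here, no measured step covers this change. The expectation is a downward step beyond the usual scatter, estimated as an at least 5.5-fold lower number from compound 3 to compound 4 (0.74 log units; beyond the scatter). For compound 4 the estimated solubility in this assay is 30 ug/mL, expected within 10 ug/mL to 90 ug/mL.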

Compound 4, solubility: 24 ug/mL
Compound 4: the middle estimate sits 1.3-fold (0.10 log units) above what was measured; low and high end bracket the measured number.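

In this assay, compound 3 gives >= 165 ug/mL, which is a limit and not a number. Replacing oxan-4-yl with 4-methylphenyl on a saturated chain carbon bound to an aromatic nitrogen gives an at least 6.8-fold lower number from compound 3 to compound 4 (0.83 log units; beyond the scatter), the only one-place comparison among the compounds shown, and it establishes that a change at this position alone can move the read-out beyond the scatter. The step is only a lower bound on the size of the change because one end of it is a limit: the limit of >= 165 ug/mL in this assay, at which 1 of the 4 values shown sits.

As far as these compounds go, it remains open how much of the step belongs to the methyl of 4-methylphenyl and how much to the ring exchange itself, which plain benzyl on the same core with the cyclopropyl amide would separate. From the compounds shown here alone, it also remains open how this position reads with an amine, such as (piperidin-4-yl)methyl.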